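The source may hold more compounds than are shown below. What is called first, only, known or untested is meant among the compounds shown, and "the series" means these compounds.

Measured so far:
compound 1 `COc1ccc(Oc2ccc3c(NCCCNCc4cc(F)ccc4OC)ccnc3c2)cc1`: 7000 nM
compound 2 `FC(F)(F)c1cc(-c2ccc3c(NCCCNCc4ccco4)ccnc3c2)cc(C(F)(F)F)c1`: 2410 nM
compound 3 `COc1ccc(Oc2ccc3c(NCCCNCc4cccc(OC)c4O)ccnc3c2)cc1`: 5500 nM

In an ADME assay on HepG2 cells (Homo sapiens) for cytotoxicity, read by luminescence, CellTiter-Glo and ATP content, with a stated time of 72 h (a higher number here means that more compound is needed for the effect, a lower number that less compound is needed), compound 1 stands highest of the three numbers. Compound 3 is nearest, a 1.3-fold lower number from compound 1 to compound 3 (0.10 log units; within the scatter). Among the compounds with values here, compound 2 is furthest; its number is lower than that of compound 1 beyond the scatter, but the two differ in more than one place, so no single step joins them. Compound 4 `COc1ccc(F)cc1CNCCCNc1ccnc2cc(CC(C)C)ccc12` is not yet measured. Its change from compound 1 is isobutyl in place of 4-methoxyphenoxy on an aromatic carbon. Within the data shown here, the one measured step, from compound 1 to compound 3, concerns a saturated chain carbon and not the core, so it says little here; the gap to compound 2 hints that a smaller, ring-free group on the core may lower the number. Compound 4 is therefore expected to show a 1.6-fold lower number from compound 1 to compound 4 (0.19 log units; within the scatter). The estimate for compound 4 is 4500 nM, with a range from 1500 nM to 13000 nM.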

Compound 4, half-maximal effective concentration: 2900 nM
Estimate against measurement, compound 4: 1.6-fold (0.19 log units) above; measured number inside the range.
By their numbers in this assay, from the lowest: compounds 2, 4, 3 and 1 (each within the scatter of the next, the first and the last beyond it).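

In this assay, within the data shown here, the change on the aromatic carbon of the shared core, isobutyl in place of 4-methoxyphenoxy, gives a 2.4-fold lower number from compound 1 to compound 4 (0.38 log units; beyond the scatter) and is the first single step here to lie beyond the scatter. The entering group lacks the six-membered aromatic ring and the hydrogen-bond acceptors of the leaving group, and this one step cannot separate those differences. Nothing available explains the shift. Going by these compounds, whether a carboxylic acid, a morpholine or a longer alkyl chain on this carbon would lower the number further remains open, as does whether isobutyl acts alike alongside the 2-hydroxy-3-methoxyphenyl group of compound 3.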